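A few compounds are considered here, and "the series" means these few. Any claim that something is new, unique, unknown or untested is made for them only; others in the source may bear on it.

Three compounds built on a shared core have been run through a functional assay on HeLa cells (Homo sapiens) for cytotoxicity, read by MTT assay, with a stated time of 72 h, tested at 10 uM; on this read-out higher numbers stand for more inhibition of growth at the one concentration tested and lower numbers for less inhibition of growth. Compound 1 `Cc1ccnc(/C(N)=N/NC(=S)N2CCOCC2)c1` gives 49.1% in this assay. Compound 2 `Cc1cccc(/C(N)=N/NC(=S)N2CCSCC2)n1` gives 67.6% in this assay, and compound 3 `Cc1ccnc(/C(N)=N/NC(=S)N2CCSCC2)c1` gives 39.2% in this assay. Compound 2 stands highest of the three, and its gaps to both compound 1 and compound 3 lie beyond the usual scatter. Compound 1 and compound 3 differ in one place, (morpholin-4-yl in place of thiomorpholin-4-yl on a thiocarbonyl carbon), and that step is a number 9.9 percentage points higher from compound 3 to compound 1 (within the scatter). Compound 2 and compound 3 are built from the same atoms joined differently; the difference between the two cores is not broken down here.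

Compound 4 `Cc1cccc(/C(N)=N/NC(=S)N2CCOCC2)n1` has not yet been measured in this assay. Among the measured compounds shown here, it is derived from compound 2 by the change (morpholin-4-yl in place of thiomorpholin-4-yl on a thiocarbonyl carbon), and this is the same change as the one that takes compound 3 to compound 1, made at the same place. Because that earlier step was a number 9.9 percentage points higher from compound 3 to compound 1 (within the scatter), only a small shift from compound 2 to compound 4 is expected, estimated as a number 4.4 percentage points higher from compound 2 to compound 4 (within the scatter). On that basis compound 4 is expected to give about 72% in this assay, with the estimate most likely falling between 56% and 86%.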

Compound 4, percent growth inhibition at one concentration: 85.4%
Beside the measured number, compound 4's estimate is 13.4 percentage points below it; the measured number falls inside the stated range.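

In this assay, the change from thiomorpholin-4-yl to morpholin-4-yl on a thiocarbonyl carbon is a number 17.8 percentage points higher from compound 2 to compound 4 (beyond the scatter). Set beside the same change on the core of compound 3, this gives two steps of the same sign whose sizes cannot be told apart, so within this pair of cores the step carries over as far as the data can show: the same change on two cores in this assay, a number 9.9 percentage points higher (within the scatter) from compound 3 to compound 1 and a number 17.8 percentage points higher (beyond the scatter) from compound 2 to compound 4, 7.9 percentage points apart, within the scatter of two such steps This does not establish a rule for the series: only the step on the core of compound 2 stands clear of the scatter by itself, two pairs say nothing about any further core, and the numbers give no reason why the change acts as it does.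

The compounds shown leave open how other groups on the thiocarbonyl carbon would compare with morpholin-4-yl and thiomorpholin-4-yl on these two cores, for instance a piperidin-1-yl ring, a piperazine ring or an open-chain dimethylamino group. They also leave open whether the step seen here would hold at other concentrations or in other cell lines, as all of these numbers come from a single concentration in HeLa cells.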